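This account rests on a few compounds, and the source may have more. Where it says the series, first, only, none or still open, it means among the compounds named here.

In a functional assay on NCI-H1299 cells (Homo sapiens) for antiproliferative activity, read by MTT assay, with a stated time of 48 h (on this read-out lower numbers stand for stronger inhibition and higher numbers for weaker inhibition), compound 1 `Cc1ccc2c(c1)C1(C(=O)N2C)C(C#N)=C(N)Oc2cc3oc(-c4ccccc4)cc(=O)c3c(O)c21` gives 10200 nM on the shared core. Compound 3 `CN1C(=O)C2(C(C#N)=C(N)Oc3cc4oc(-c5ccccc5)cc(=O)c4c(O)c32)c2cc(Cl)ccc21` gives 11200 nM and is its nearest neighbour among the numeric values. Compound 2 `CN1C(=O)C2(C(C#N)=C(N)Oc3cc4oc(-c5ccccc5)cc(=O)c4c(O)c32)c2cccc(Cl)c21` gives only a limit of the assay (> 50000 nM). Compound 4 `CN1C(=O)C2(C(C#N)=C(N)Oc3cc4oc(-c5ccccc5)cc(=O)c4c(O)c32)c2cc(Br)ccc21` differs from compound 1 by bromo in place of methyl on an aromatic carbon in words, bromo in place of methyl on an aromatic carbon. Among the measured compounds shown here, the one measured step that bears on this is chloro in place of methyl on that same carbon, a 1.1-fold higher number from compound 1 to compound 3 (0.04 log units; within the scatter), so no step beyond the scatter is expected in this assay. The step expected is a 1.0-fold lower number from compound 1 to compound 4 (0.01 log units; within the scatter). Compound 4 is estimated at 10000 nM (range 5000 nM to 22000 nM).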

Compound 4, half-maximal inhibitory concentration: 7610 nM
The estimate for compound 4 lay 1.3-fold (0.12 log units) above the measured number; low and high end bracket the measured number.
By their numbers in this assay, from the lowest: compounds 4, 1 and 3 (each within the scatter of the next). At a limit, above all of these: compound 2.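

Bromo is the second replacement for methyl on this aromatic carbon, and in this assay it gives a 1.3-fold lower number from compound 1 to compound 4 (0.13 log units; within the scatter). Bromo in place of chloro gives a 1.5-fold lower number from compound 3 to compound 4 (0.17 log units; within the scatter), so methyl, chloro and bromo on this carbon are not separated by this read-out. No measurement shown here bears on why these three groups are not separated.

As far as these compounds go, whether an amine or a carboxylic acid on this carbon would give a step beyond the scatter stays open. So does the outcome for a longer chain such as propyl there.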